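Moving a Chlorine Around a Benzyl Ring in Rat Artery

The compounds below may be only part of what the source reports. "The series", "measured", "known", "first", "only" and "open" are said of these compounds alone.

Compound 1 `COc1ccc(C2N=C(SCc3cccc(Cl)c3)NC(C)=C2C(=O)Nc2ccc(F)cc2)cc1OC` and compound 2 `COc1ccc(C2N=C(SCc3ccc(Cl)cc3)NC(C)=C2C(=O)Nc2ccc(F)cc2)cc1OC` share one core and differ only in 4-chlorophenyl in place of 3-chlorophenyl on a saturated chain carbon bound to a sulfur. In a functional assay on the whole organism (artery, strain albino) with Rattus norvegicus as the target, with a stated time of 300 min, at a dose of 10 mg/kg by the oral route (on this read-out higher numbers stand for more inhibition at the one dose given (going by the name of the read-out) and lower numbers for less inhibition), compound 1 gives 16.4%, while compound 2 gives 31.3%, so this change produced a number 14.9 percentage points higher from compound 1 to compound 2 (beyond the scatter). Compound 3 `CC1=C(C(=O)Nc2ccc(Br)cc2)C(c2ccc(Cl)cc2Cl)N=C(SCc2cccc(Cl)c2)N1` is built on a different core; the difference between the two cores is not broken down here. In this assay compound 3 gives 18.5%, a number that sits within the scatter of compound 1 and lies below compound 2 by more than the scatter.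

Compound 4 `CC1=C(C(=O)Nc2ccc(Br)cc2)C(c2ccc(Cl)cc2Cl)N=C(SCc2ccc(Cl)cc2)N1` has not yet been measured. It differs from compound 3 by 4-chlorophenyl in place of 3-chlorophenyl on a saturated chain carbon bound to a sulfur, the same change that separates compound 1 from compound 2, now made on the other core. Because that earlier change gave a number 14.9 percentage points higher from compound 1 to compound 2 (beyond the scatter), a rise of similar size is expected here, though one pair is a thin basis and the second core may not respond in the same way. The expected step is a number 11.5 percentage points higher from compound 3 to compound 4 (beyond the scatter). Compound 4 is therefore estimated at 30%, most likely falling between 15% and 45%.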

Compound 4, a percentage reported as inhibition, in the whole organism at one dose (the size of the read-out at that dose, not a potency): 38.5%
For compound 4 the middle estimate is 8.5 percentage points below the measured one; the range from low to high includes it.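

In this assay the swap from 3-chlorophenyl to 4-chlorophenyl gave a number 20 percentage points higher from compound 3 to compound 4 (beyond the scatter) on the core of compound 3, so the rise seen on the first core appeared on the second as well. The two rises are about the same size, which means that in this series the change carried over from one core to the other without a clear loss or gain: the same change on two cores in this assay, a number 14.9 percentage points higher (beyond the scatter) from compound 1 to compound 2 and a number 20 percentage points higher (beyond the scatter) from compound 3 to compound 4, 5.1 percentage points apart, within the scatter of two such steps. Among these compounds, this rests on only two pairs at a single dose, so it does not show that the change would work on any other core, why the 4-chlorophenyl group gives the higher number, or how potency differs, as a percentage at one dose is not a potency.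

The compounds shown leave open whether the rise depends on chlorine itself, since a benzyl ring carrying fluorine, a methoxy group or a carboxylic acid in its place does not appear among them. Also open, going by these compounds, is what a plain benzyl group or a longer chain linking the sulfur to the ring would do.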